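A Halogenated Aryl Change on a Shared Core

A few compounds are considered here, and "the series" means these few. Any claim that something is new, unique, unknown or untested is made for them only; others in the source may bear on it.

Measured compounds:
- Compound 1, `CC(C)(C)C1=NN(c2ccc(C(=O)O)cc2)C(c2ccc(O)cc2)C1`: in an assay on isolated protein for inhibition of protein kinase C zeta type (Homo sapiens), with a stated time of 4 min (on this read-out lower numbers stand for stronger inhibition and higher numbers for weaker inhibition), compound 1 gives "not determined" (no result reported).
- Compound 2, `CC(C)(C)C1=NN(c2cccc(C(F)(F)F)c2)C(c2ccc(O)cc2)C1`: in this assay compound 2 gives 2700 nM.
- Compound 3, `Cc1cccc(N2N=C(C(C)(C)C)CC2c2ccc(O)cc2)c1`: in this assay compound 3 gives 3500 nM.

Compound 3 and compound 2 lie within the usual scatter of each other on this assay, so the two cannot be told apart; compound 1 contributes no number. Within the data shown here, the only measured step that bears on the next change is the one that swapped a group on the same aromatic ring, a 1.3-fold higher number from compound 2 to compound 3 (0.11 log units; within the scatter), a step too small to count as real movement.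

Compound 4, `CC(C)(C)C1=NN(c2ccc(F)c(Cl)c2)C(c2ccc(O)cc2)C1`, is not yet measured. It differs from compound 3 by 3-chloro-4-fluorophenyl in place of 3-methylphenyl on an amine nitrogen in a ring. Among the measured compounds shown here, because the one comparable change, a 1.3-fold higher number from compound 2 to compound 3 (0.11 log units; within the scatter), stayed within the scatter, the expectation is that this further change on the same ring will also produce no step beyond the scatter, with at most a slight move toward a lower number. Compound 4 is therefore estimated at 2800 nM, with a range from 1000 nM to 8000 nM. The step this estimate implies, a 1.3-fold lower number from compound 3 to compound 4 (0.10 log units; within the scatter), is expected to stay small.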

Compound 4, half-maximal inhibitory concentration: 900 nM
For compound 4 the middle estimate is 3.1-fold (0.49 log units) above the measured one; measured number below the stated range.
By their numbers in this assay, from the lowest: compound 4; then compounds 2 and 3 (each within the scatter of the next).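

In this assay the group on the amine nitrogen in the ring now proves able to move the read-out: the change from 3-methylphenyl to 3-chloro-4-fluorophenyl gives a 3.9-fold lower number from compound 3 to compound 4 (0.59 log units; beyond the scatter) and so clears the usual scatter. Among these compounds, the earlier swap on this ring (a 1.3-fold higher number from compound 2 to compound 3 (0.11 log units; within the scatter)) could not show this, so the new step is the first sign that this position responds to what its aryl ring carries, though the size is only modest. No supporting evidence is available to explain why the number falls.

From the compounds shown here alone, the change removes a methyl and adds a chlorine and a fluorine at once, so it remains open whether 3-chlorophenyl or 4-fluorophenyl alone would give a similar step. Going by these compounds, how an amine or a methoxy group on this ring would read also remains open.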